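A few compounds are considered here, and "the series" means these few. Any claim that something is new, unique, unknown or untested is made for them only; others in the source may bear on it.

Compound 1 `COc1cc(C(=O)O)ccc1OCCCCOc1ccc(C(=O)CC(C)(C)C)c(O)c1C` — 98.6%
Compound 2 `Cc1c(OCCCCOc2ccc(C(=O)O)cc2Cl)ccc(C(=O)CC2CCCC2)c1O` — 82.2%
Compound 3 `Cc1cc(OCCCCOc2ccc(C(=O)CC3CCCC3)c(O)c2C)ccc1C(=O)O` — 83.6%

These three compounds share a core and were measured in an assay on HEK293 cells for positive allosteric modulation of metabotropic glutamate receptor 2 (Rattus norvegicus), read by thallium flux, with a stated time of 2.5 min; on this read-out lower numbers stand for smaller maximal responses and higher numbers for larger maximal responses. Compound 3 stands second highest of the three numbers: its nearest neighbour is compound 2, which lies within the scatter of it, while compound 1 lies beyond the scatter above it. For the measured compounds named here, the one step that differs in a single place, a number 1.4 percentage points higher from compound 2 to compound 3 (within the scatter), concerns a chloro-bearing and a methyl-bearing aryl group on an oxygen on a saturated carbon and stayed within the scatter.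

Compound 4 `Cc1c(OCCCCOc2ccc(C(=O)O)c(Cl)c2)ccc(C(=O)CC2CCCC2)c1O` has not yet been measured. It differs from compound 3 by chloro in place of methyl on an aromatic carbon. Going by the values given here, the only comparable exchange of chloro and methyl on this aryl group, the step from compound 2 to compound 3, was within the scatter, so compound 4 is expected to change little in this assay; the step of a number 0.6 percentage points lower from compound 3 to compound 4 (within the scatter) is estimated to stay within the scatter. Compound 4 is therefore expected to give about 83%, with a likely range from 72% to 94%.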

Compound 4, largest response reached (reported as percent of maximum), in percent of the reference or control that the assay uses: 80.8%
Compound 4: middle estimate off by 2.2 percentage points, on the high side; the range from low to high includes it.
By their numbers in this assay, from the lowest: compounds 4, 2 and 3 (each within the scatter of the next); then compound 1.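

In this assay, for the compounds shown here, chloro in place of methyl on the same aromatic carbon, ortho to a carboxy group, gives a number 2.8 percentage points lower from compound 3 to compound 4 (within the scatter), the first direct exchange of these two groups at this position. Shifting the chloro, with 4-carboxy-3-chlorophenyl in place of 4-carboxy-2-chlorophenyl, gives a number 1.4 percentage points lower from compound 2 to compound 4 (within the scatter), so among these three compounds neither the group nor the place of the chloro separates the maximal responses. No measurement is available that would explain this lack of separation.

As far as these compounds go, whether a larger or different group on this carbon, such as methoxy, an amine or a nitrile, would move the response beyond the scatter remains open. Compound 1 differs from these compounds in more than one place, so the compounds shown cannot assign its higher response to any single part of its structure.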